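The source may report more compounds than this note shows. Statements on the series, on what has been measured and on what is new or still open speak of the compounds shown alone.

Measured so far in a functional assay on MDA-MB-231 cells (Homo sapiens) for antiproliferative activity, read by MTT assay, with a stated time of 48 h; on this read-out higher numbers stand for weaker inhibition and lower numbers for stronger inhibition:
- compound 1 `C=CS(=O)(=O)N1CCN(c2ncnc3sc(-c4ccccc4)cc23)CC1`: 54200 nM
- compound 2 `C=CS(=O)(=O)N1CCN(c2ncnc3sc(-c4ccc(C(F)(F)F)cc4)cc23)CC1`: 6410 nM
- compound 3 `C=CS(=O)(=O)N1CCN(c2ncnc3sc(-c4cc(Br)cnc4F)cc23)CC1`: 24100 nM

Compound 3, at 24100 nM, holds the middle place among these numbers. It lies on one side of a 2.2-fold lower number from compound 1 to compound 3 (0.35 log units; beyond the scatter) and on the other of a 3.8-fold higher number from compound 2 to compound 3 (0.58 log units; beyond the scatter).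

Compound 4 `C=CS(=O)(=O)N1CCN(c2ncnc3sc(-c4cn(C)nc4C(F)(F)F)cc23)CC1` keeps the shared core and changes only the aromatic group next to the ring sulfur: 1-methyl-3-(trifluoromethyl)-1H-pyrazol-4-yl in place of 5-bromo-2-fluoropyridin-3-yl on an aromatic carbon. In words, 1-methyl-3-(trifluoromethyl)-1H-pyrazol-4-yl replaces 5-bromo-2-fluoropyridin-3-yl.

Within the data shown here, no measured step makes this exact swap. The closest guide is an 8.5-fold lower number from compound 1 to compound 2 (0.93 log units; beyond the scatter), where trifluoromethyl replaces hydrogen on a phenyl ring. The new group also carries trifluoromethyl, but on a different ring, so that modest gain may carry over only in part. Swaps at this same place have so far given only modest steps, as in a 2.2-fold lower number from compound 1 to compound 3 (0.35 log units; beyond the scatter).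

The expected change is small, a 1.7-fold lower number from compound 3 to compound 4 (0.24 log units; within the scatter), and no step beyond the scatter is firmly expected. For compound 4 the estimated value is 14000 nM, with an expected range of 5000 nM to 40000 nM.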

Compound 4, half-maximal inhibitory concentration: 10400 nM
Beside the measured number, compound 4's estimate is 1.3-fold (0.13 log units) above it; measured number inside the range.
By their numbers in this assay, from the lowest: compounds 2 and 4 (each within the scatter of the next); then compound 3; then compound 1.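

A five-membered aromatic ring carrying trifluoromethyl is tolerated at this position next to the ring sulfur, and a 2.3-fold lower number from compound 3 to compound 4 (0.36 log units; beyond the scatter) shows it improving on the bromofluoropyridine group. The step of a 1.6-fold higher number from compound 2 to compound 4 (0.21 log units; within the scatter) lies within the scatter, so 1-methyl-3-(trifluoromethyl)-1H-pyrazol-4-yl and 4-(trifluoromethyl)phenyl cannot be ranked, while a 5.2-fold lower number from compound 1 to compound 4 (0.72 log units; beyond the scatter) confirms that both trifluoromethyl-bearing groups outdo plain phenyl, with neither compound 1 nor compound 3 carrying that group. Nothing available here explains these differences.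

It remains open how much of the gain belongs to the trifluoromethyl group itself, since the same pyrazole ring without it is not among these compounds. Also open, from the compounds shown here alone, is how this position would respond to a ring carrying an amine or a carboxylic acid.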